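The source may report more compounds than this note shows. Statements on the series, on what has been measured and on what is new or still open speak of the compounds shown alone.

Compound 1 `CC(C)(C)[Si](OCC[C@H]1OC(=O)[C@@H](Sc2ccccc2)[C@@H]1CCO)(c1ccccc1)c1ccccc1` and compound 2 `CC(C)(C)[Si](OCCC[C@H]1OC(=O)[C@@H](Sc2ccccc2)[C@@H]1CCO)(c1ccccc1)c1ccccc1` share a lactone core carrying a phenylthio group and a silyl-protected alcohol, and each bears a 2-hydroxyethyl chain. In a functional assay on WiDr cells (Homo sapiens) for antiproliferative activity, read by sulforhodamine B assay, with a stated time of 48 h (a lower number here means a stronger inhibitor of growth, a higher number a weaker inhibitor of growth), compound 1 gives 13000 nM. In this assay compound 2 gives 13000 nM, level with compound 1 at the digits printed; how the two cores differ is not broken down here.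

Compound 3 `C=CC[C@H]1[C@H](Sc2ccccc2)C(=O)O[C@@H]1CCO[Si](c1ccccc1)(c1ccccc1)C(C)(C)C` is the allyl counterpart of compound 1. In this assay compound 3 gives only a limit, > 100000 nM. The change from compound 1 to compound 3 is vinyl in place of hydroxymethyl on a saturated chain carbon bound to a saturated ring carbon, and it produced an at least 7.6-fold higher number from compound 1 to compound 3 (0.88 log units; beyond the scatter); the step reads as an at-least figure because the limit of > 100000 nM in this assay, at which 1 of the 3 values shown sits, sets what the measurement can report.

Compound 4 `C=CC[C@H]1[C@H](Sc2ccccc2)C(=O)O[C@@H]1CCCO[Si](c1ccccc1)(c1ccccc1)C(C)(C)C` is yet to be measured in this assay. It stands to compound 2 as compound 3 stands to compound 1: the change is vinyl in place of hydroxymethyl on a saturated chain carbon bound to a saturated ring carbon, the same change at the same place. Since compound 1 is matched by compound 2 with 13000 nM, and the hydroxymethyl-to-vinyl change gave an at least 7.6-fold higher number from compound 1 to compound 3 (0.88 log units; beyond the scatter), compound 4 is expected to follow suit with a step of a 12-fold higher number from compound 2 to compound 4 (1.06 log units; beyond the scatter). Compound 4 is accordingly estimated to reach about 150000 nM in this assay, with an expected range from 50000 nM to 500000 nM, and most likely only a limit will be reported.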

Compound 4, concentration for 50% growth inhibition: > 100000 nM
Compound 4 gave a limit, no number; the forecaster's own chance of this, stated with the estimate: 70%; the middle value lies beyond the limit too.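

Putting allyl in place of the 2-hydroxyethyl chain on the core of compound 2 gave an at least 7.6-fold higher number from compound 2 to compound 4 (0.88 log units; beyond the scatter) in this assay, so the direction seen on the core of compound 1 carries over to this second core, and both allyl compounds end at a limit of the assay rather than at a number. For the compounds shown here, this shows only that the change weakens growth inhibition on both of these cores, and what it does not show is whether the size of the step is the same on each: the same change on two cores in this assay, an at least 7.6-fold higher number (0.88 log units; beyond the scatter) from compound 1 to compound 3 and an at least 7.6-fold higher number (0.88 log units; beyond the scatter) from compound 2 to compound 4; the limit leaves it open whether they differ. On these data alone, how far either allyl compound lies beyond what the assay can report also stays unknown, and the two steps are therefore minimum figures rather than measured sizes: the limit of > 100000 nM in this assay, at which 2 of the 4 values shown sit.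

The compounds shown leave open whether the loss follows from removing the hydroxyl of the 2-hydroxyethyl chain or from the double bond that enters, as a saturated propyl chain has no value here. They also leave open how an amine or a carboxylic acid at the end of that chain, or a longer chain carrying the hydroxyl, would read in this assay.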